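Series notes: pyrimidin-5-yl replacing pyridin-4-yl at compound 3

The compounds below may be only part of what the source reports. "The series", "measured", "known", "first", "only" and "open" are said of these compounds alone.

Measured so far, in an assay on HT-29 cells for inhibition of Serine-protein kinase ATM (Homo sapiens), read by fluorescence, with a stated time of 1 h; on this read-out lower numbers stand for stronger inhibition and higher numbers for weaker inhibition:
compound 1 `C[C@@H](Nc1c(C(N)=O)cnc2ccc(-c3cccnc3)cc12)c1ccc(Cl)cc1` gives 109 nM
compound 2 `NC(=O)c1cnc2ccc(-c3cccnc3)cc2c1NC1CCCCC1` gives 132 nM
compound 3 `CCC(CC)CNc1c(C(N)=O)cnc2ccc(-c3ccncc3)cc12` gives 418 nM

Compound 3 shows the highest number of the three. Its nearest neighbour is compound 2, and the gap between them lies beyond the usual scatter; the gap to compound 1 is wider still. Going by the values given here, the one single-place step available, a 1.2-fold higher number from compound 1 to compound 2 (0.08 log units; within the scatter), concerns the group on the nitrogen and lies within the scatter. Compound 3 differs from compound 2 in two places at once, so the separate weight of its pyridin-4-yl ring against pyridin-3-yl cannot be read off. Among the compounds with values here, no measured step touches the aryl ring at all.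

Compound 4 `CCC(CC)CNc1c(C(N)=O)cnc2ccc(-c3cncnc3)cc12` is the next member. The change from compound 3 is pyrimidin-5-yl in place of pyridin-4-yl on an aromatic carbon. Within the data shown here, with no measured step bearing on this position, the expectation rests on the absence of evidence for large effects elsewhere in the set: the step of a 1.0-fold lower number from compound 3 to compound 4 (0.02 log units; within the scatter) is expected to stay within the scatter, direction uncertain. In this assay compound 4 is therefore estimated at 400 nM, with a range from 150 nM to 1100 nM.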

Compound 4, half-maximal inhibitory concentration: 1840 nM
Compound 4: the middle estimate sits 4.6-fold (0.66 log units) below what was measured; the whole stated range lies below it.
By their numbers in this assay, from the lowest: compounds 1 and 2 (each within the scatter of the next); then compound 3; then compound 4.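

The aryl position on the shared core now has a measured step in this assay: with the group on the nitrogen held constant, pyrimidin-5-yl in place of pyridin-4-yl gives a 4.4-fold higher number from compound 3 to compound 4 (0.64 log units; beyond the scatter). Going by these compounds alone, the only earlier single-place step, a 1.2-fold higher number from compound 1 to compound 2 (0.08 log units; within the scatter), concerned the group on the nitrogen and stayed within the scatter, whereas this one lies beyond it, so the read-out responds to the identity of this ring at an unchanged count of heavy atoms, with one ring carbon exchanged for a nitrogen. Nothing available accounts for the rise in the number, and its cause stays unassigned.

The compounds shown leave open how pyridin-3-yl, carried by compound 1 and compound 2, ranks against pyridin-4-yl and pyrimidin-5-yl on a common nitrogen substituent, as no single-place pair among them links these rings. Also open, from the compounds shown here alone, are how a plain phenyl ring or an aminopyridine would read on this aromatic carbon, and whether the step would hold with cyclohexyl or 1-(4-chlorophenyl)ethyl on the nitrogen.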